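Methyl on the piperidine ring of compound 2

A few compounds are considered here, and "the series" means these few. Any claim that something is new, unique, unknown or untested is made for them only; others in the source may bear on it.

Measured so far:
compound 1 `COc1cc2c(Oc3ccc(NC(=O)c4nn(-c5cccc(F)c5)c(=O)cc4C)cc3F)ccnc2cc1OCCCN1CCCC1` gives 280 nM
compound 2 `COc1cc2c(Oc3ccc(NC(=O)c4nn(-c5cccc(F)c5)c(=O)cc4C)cc3F)ccnc2cc1OCCCN1CCCCC1` gives 360 nM

Among the compounds with values here, in a functional assay on NCI-H460 cells (Homo sapiens) for inhibition, read by MTT assay, with a stated time of 72 h (on this read-out lower numbers stand for stronger inhibition and higher numbers for weaker inhibition), compound 2 holds the higher of the two numbers, but its only neighbour is compound 1, and the step of a 1.3-fold higher number from compound 1 to compound 2 (0.11 log units; within the scatter) lies within the scatter, so compound 2 stands on a par with compound 1 rather than apart from it.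

Compound 3 `COc1cc2c(Oc3ccc(NC(=O)c4nn(-c5cccc(F)c5)c(=O)cc4C)cc3F)ccnc2cc1OCCCN1CCC(C)CC1` differs from compound 2 by methyl in place of hydrogen on a saturated ring carbon. Within the data shown here, no measured step alters a substituent on this saturated ring; the one step at the same end of the chain, a 1.3-fold higher number from compound 1 to compound 2 (0.11 log units; within the scatter), exchanged the whole ring and stayed within the scatter. Among the measured compounds shown here, that single step is the only guide, and it gives no reason to expect a move beyond the scatter in this assay in either direction.

Compound 3 is therefore estimated at 400 nM, within 180 nM to 900 nM, the expected step from compound 2 being a 1.1-fold higher number from compound 2 to compound 3 (0.05 log units; within the scatter).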

Compound 3, half-maximal inhibitory concentration: 250 nM
Beside the measured number, compound 3's estimate is 1.6-fold (0.20 log units) above it, and the stated range covers the measured number.
By their numbers in this assay, from the lowest: compounds 3, 1 and 2 (each within the scatter of the next).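

In this assay, the earlier step exchanged the whole ring, whereas this one alters a substituent on it: methyl on the saturated ring carbon three ring bonds from the ring nitrogen gives a 1.4-fold lower number from compound 2 to compound 3 (0.16 log units; within the scatter) and so leaves the read-out within the scatter. The comparison with the pyrrolidin-1-yl end gives a 1.1-fold lower number from compound 1 to compound 3 (0.05 log units; within the scatter) and is also within the scatter, so pyrrolidin-1-yl, piperidin-1-yl and 4-methylpiperidin-1-yl cannot be told apart on these numbers. No evidence is available that bears on this result.

Open, on these data alone, is whether this ring carbon tolerates something other than methyl, such as a hydroxyl or a carboxylic acid. Also open, as far as these compounds go, is whether a morpholine at the chain end, or a longer chain, would move the number beyond the scatter.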